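The compounds below may be only part of what the source reports. "The series", "measured", "known", "first", "only" and "open" are said of these compounds alone.

Measured compounds:
compound 1 `N#CC1(NC(=O)[C@@H]2C[C@@H](S(=O)(=O)c3ccccc3)C[C@H]2C(=O)N2CCOCC2)CC1` — 0.7 nM
compound 2 `N#CC1(NC(=O)[C@@H]2C[C@@H](S(=O)(=O)c3ccccc3)C[C@H]2C(=O)N2CC3(COC3)C2)CC1` — 3 nM
compound 3 `N#CC1(NC(=O)[C@@H]2C[C@@H](S(=O)(=O)c3ccccc3)C[C@H]2C(=O)N2CCCC2)CC1` — 2 nM

All three share one core and differ only in the amine on the carbonyl carbon. In an assay on isolated protein for inhibition of cathepsin S (Homo sapiens), read by fluorescence, with a stated time of 20 min (on this read-out higher numbers stand for weaker inhibition and lower numbers for stronger inhibition), compound 3 gives the second highest number of the three. Its nearest neighbour is compound 2, and the step of a 1.5-fold lower number from compound 2 to compound 3 (0.18 log units; within the scatter) lies within the scatter. Its furthest neighbour is compound 1, which gives the lowest number, and the step of a 2.9-fold higher number from compound 1 to compound 3 (0.46 log units; beyond the scatter) is beyond the scatter.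

Compound 4 `N#CC1(NC(=O)[C@@H]2C[C@@H](S(=O)(=O)c3ccccc3)C[C@H]2C(=O)N2CCC2)CC1` is the next member. It differs from compound 3 by azetidin-1-yl in place of pyrrolidin-1-yl on a carbonyl carbon.

Among the compounds with values here, the steps that bear on this change are all at the same carbonyl carbon: a 2.9-fold higher number from compound 1 to compound 3 (0.46 log units; beyond the scatter) and a 4.3-fold higher number from compound 1 to compound 2 (0.63 log units; beyond the scatter) are both modest, and a 1.5-fold lower number from compound 2 to compound 3 (0.18 log units; within the scatter) is within the scatter. Within the data shown here, no measured step shows a contraction of a five-membered ring to a four-membered ring, so the closest guide is that exchanging one saturated amine for another here moves the number by a modest amount at most. The expected step of a 1.5-fold higher number from compound 3 to compound 4 (0.18 log units; within the scatter) is therefore small and not clearly beyond the scatter. Compound 4 is expected to give 3 nM in this assay, with a range from 1 nM to 9 nM.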

Compound 4, half-maximal inhibitory concentration: 10 nM
Beside the measured number, compound 4's estimate is 3.3-fold (0.52 log units) below it; the measured number lies above the stated range.
By their numbers in this assay, from the lowest: compound 1; then compounds 3 and 2 (each within the scatter of the next); then compound 4.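

In this assay, within the data shown here, the amine on the carbonyl carbon can move the number further than the earlier compounds showed: the step of a 14-fold higher number from compound 1 to compound 4 (1.15 log units; beyond the scatter) is large, and it is the first large step at this position. Shortening the ring from pyrrolidin-1-yl to azetidin-1-yl is itself beyond the scatter, with a 5.0-fold higher number from compound 3 to compound 4 (0.70 log units; beyond the scatter) as the step, so compound 4 is the weakest of the four. A four-membered ring in the amine does not by itself set this level, since the group in compound 2 also holds such rings and the step of a 3.3-fold higher number from compound 2 to compound 4 (0.52 log units; beyond the scatter) still separates the two compounds, though no evidence at hand accounts for any of these steps.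

Piperidin-1-yl, the all-carbon counterpart of morpholin-4-yl, would show whether the ring oxygen or the ring size sets the low number of compound 1, and a simple open-chain dimethylamino group would show whether a ring is needed at all. As far as these compounds go, whether the loss seen with azetidin-1-yl can be recovered on that small ring stays open too, and 3-hydroxyazetidin-1-yl or 3-methoxyazetidin-1-yl would test this.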